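Isopropyl to Methyl on the Aromatic Ring: Expected Cytotoxicity

The source may hold more compounds than are shown below. What is called first, only, known or untested is meant among the compounds shown, and "the series" means these compounds.

Measured compounds:
Compound 1, `O=c1ccn(CCCCCOc2ccc(Br)cc2)c(=O)[nH]1`: 100000 nM
Compound 2, `CC(C)c1ccc(OCCCCCn2ccc(=O)[nH]c2=O)cc1`: 100000 nM

Both measured compounds share one core and differ only in the group on an aromatic carbon. In an ADME assay on HEL cells (Homo sapiens) for cytotoxicity, read by microscopy (on this read-out higher numbers stand for lower toxicity in this test and lower numbers for higher toxicity in this test), compound 1 gives 100000 nM, and compound 2 gives 100000 nM. The single measured step, isopropyl in place of bromo on an aromatic carbon, produced no change at the digits printed from compound 1 to compound 2 (within the scatter), so compound 2 stands level with compound 1 on the numbers shown.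

Compound 3, `Cc1ccc(OCCCCCn2ccc(=O)[nH]c2=O)cc1`, differs from compound 2 by methyl in place of isopropyl on an aromatic carbon. Among the compounds with values here, the one step that bears on this change, the bromo-to-isopropyl exchange at the same place, gave no change beyond the scatter, which suggests that a second exchange of the group at that position is also expected to leave the read-out where it is, with an estimated step of no change at the digits printed from compound 2 to compound 3 (within the scatter). Compound 3 is therefore expected to give 100000 nM in this assay, with a range from 50000 nM to 200000 nM.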

Compound 3, minimum cytotoxic concentration: 100000 nM
The estimate for compound 3 equals the measured number at the digits printed; the measured number falls inside the stated range.
By their numbers in this assay, from the lowest: compounds 1, 2 and 3 (each within the scatter of the next).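

In this assay the read-out stays level when the group at this place gets smaller, with no change at the digits printed from compound 2 to compound 3 (within the scatter) as isopropyl, of 3 heavy atoms, gives way to methyl, of 1 heavy atom. Bromo can also give way to methyl, with no change at the digits printed from compound 1 to compound 3 (within the scatter) here, so three different groups on the aromatic carbon now sit level, where the earlier pair offered only two. No measurement shown here explains this flat result.

The compounds shown leave open whether an amine, a carboxylic acid or a longer chain on this aromatic carbon would also keep the read-out level. They also leave open whether any of these groups would do the same elsewhere on the ring.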